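Swapping the Nitrogen Substituent: Cyclobutyl to Isopentyl

The source may report more compounds than this note shows. Statements on the series, on what has been measured and on what is new or still open speak of the compounds shown alone.

Compound 1, `Cn1sc2cc(OCc3cccc(-c4ccc(Cl)c(C(=O)O)c4)c3)ccc2c1=O`, gives 74.7% in an assay on HEK293 cells for positive allosteric modulation of metabotropic glutamate receptor 2 (Rattus norvegicus), read by thallium flux; on this read-out higher numbers stand for larger maximal responses and lower numbers for smaller maximal responses.
Compound 2, `O=C(O)c1cc(-c2cccc(COc3ccc4c(=O)n(C5CCC5)sc4c3)c2)ccc1Cl`, gives 83% in this assay.

Compound 2 carries the number nearest the top of this pair, but its gap to compound 1 lies within the scatter, so the two cannot be told apart on this read-out. Going by the values given here, the only measured step is a number 8.3 percentage points higher from compound 1 to compound 2 (within the scatter), a change of the group on the aromatic nitrogen that left the largest response within the scatter. Compound 3, `CC(C)CCn1sc2cc(OCc3cccc(-c4ccc(Cl)c(C(=O)O)c4)c3)ccc2c1=O`, alters the same position once more: isopentyl in place of cyclobutyl on an aromatic nitrogen. Because this is again an exchange of one small carbon group for another at the place where a number 8.3 percentage points higher from compound 1 to compound 2 (within the scatter) stayed within the scatter, no movement beyond the scatter is expected in this assay for compound 3. The estimated step is a number 3 percentage points lower from compound 2 to compound 3 (within the scatter). For compound 3 the expected value is 80%, with a range from 65% to 95%. One caution remains: a single measured step is a thin basis, and a ring-to-chain exchange has not itself been tested here.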

Compound 3, largest response reached (reported as percent of maximum), in percent of the reference or control that the assay uses: 67.3%
Estimate against measurement, compound 3: 12.7 percentage points above; measured number inside the range.
By their numbers in this assay, from the lowest: compounds 3, 1 and 2 (each within the scatter of the next, the first and the last beyond it).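

In this assay, the group on the aromatic nitrogen, next to the ring sulfur, now produces its first change beyond the scatter: putting isopentyl in place of cyclobutyl gives a number 15.7 percentage points lower from compound 2 to compound 3 (beyond the scatter) and so shows that the largest response does not stay the same for every small carbon group here. The effect is limited, though, as the comparison with the methyl compound gives a number 7.4 percentage points lower from compound 1 to compound 3 (within the scatter) and the earlier exchange of methyl for cyclobutyl gave a number 8.3 percentage points higher from compound 1 to compound 2 (within the scatter), so only the cyclobutyl and isopentyl compounds can be told apart, while the methyl compound cannot be separated from either. The data offer no measurement that explains this difference between cyclobutyl and isopentyl.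

With one ring and two open chains of different lengths, the compounds shown cannot tell whether the ring, the branching or the number of carbons goes with the difference. A cyclopentyl group, a straight butyl chain or a chain ending in an amine at this nitrogen would each put a different one of these questions to the same read-out.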